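Hydroxy in place of 4-methylpiperazin-1-yl on the side chain

A few compounds are considered here, and "the series" means these few. Any claim that something is new, unique, unknown or untested is made for them only; others in the source may bear on it.

Of the compounds shown here, two sharing one core have been measured in a functional assay on Raji cells (Homo sapiens) for antiproliferative activity, read by MTT assay, with a stated time of 48 h; a lower number here means a stronger inhibitor, a higher number a weaker inhibitor. Compound 1 `N#Cc1nc2c(-c3nc4ccccc4[nH]3)c(N)n(CCO)c2nc1C#N` gives 5520 nM, and compound 2 `CN1CCN(CCCn2c(N)c(-c3nc4ccccc4[nH]3)c3nc(C#N)c(C#N)nc32)CC1` gives 2620 nM, the lower of the two numbers. Compound 3 `N#Cc1nc2c(-c3nc4ccccc4[nH]3)c(N)n(CCCO)c2nc1C#N` has not yet been measured. It carries hydroxy in place of the 4-methylpiperazin-1-yl of compound 2, on a saturated chain carbon, three bonds along the chain from an aromatic nitrogen: hydroxy in place of 4-methylpiperazin-1-yl on a saturated chain carbon, three bonds along the chain from an aromatic nitrogen. Among the measured compounds shown here, one measured step bears on this change: a 2.1-fold lower number from compound 1 to compound 2 (0.32 log units; beyond the scatter). That modest step, beyond the scatter, put (4-methylpiperazin-1-yl)methyl in place of hydroxy, two bonds along the chain from an aromatic nitrogen. The present change runs the opposite way, so a step of similar size toward a higher number is expected: a 1.9-fold higher number from compound 2 to compound 3 (0.28 log units; within the scatter). Compound 3 is estimated at 5000 nM, with an expected range from 2400 nM to 10000 nM.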

Compound 3, half-maximal inhibitory concentration: > 50000 nM
Compound 3: a limit, no number; the forecaster's own chance of this, stated with the estimate: 3%; middle value at least 10-fold (1.00 log units) away from the limit.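

Compound 3 stands at a limit of this assay, not at a number: the limit of > 50000 nM in this assay, at which 1 of the 3 values shown sits. With 3-hydroxypropyl in place of 3-(4-methylpiperazin-1-yl)propyl, the result is an at least 19-fold higher number from compound 2 to compound 3 (1.28 log units; beyond the scatter), so this exchange counts for far more on the propyl chain than the earlier 2.1-fold lower number from compound 1 to compound 2 (0.32 log units; beyond the scatter) suggested. That earlier step changed the chain and its end group together, whereas the move from 2-hydroxyethyl to 3-hydroxypropyl isolates the chain with hydroxy kept at its end, and it gives an at least 9.0-fold higher number from compound 1 to compound 3 (0.95 log units; beyond the scatter).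

The compounds shown leave open whether the full 4-methylpiperazin-1-yl ring is needed, or whether a simpler dimethylamine or a morpholine at the end of the same propyl chain would hold the number of compound 2. As far as these compounds go, how 2-(4-methylpiperazin-1-yl)ethyl or a longer chain ending in the same ring would read also remains open.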